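A few compounds are considered here, and "the series" means these few. Any claim that something is new, unique, unknown or untested is made for them only; others in the source may bear on it.

Of the compounds shown here, three built on a shared core have been tested in a functional assay on HEK293 cells for agonist activity at G-protein coupled receptor 39 (Homo sapiens), read by inositol phosphate accumulation; on this read-out higher numbers stand for an effect only at larger amounts of compound and lower numbers for an effect already at smaller amounts. Compound 1 `Cc1nc(NCc2ccc(Cl)cc2)cc(-c2ccccn2)n1` gives 81 nM and compound 3 `CNc1nc(NC2(c3ccc(Cl)cc3)CCC2)cc(-c2ccccn2)n1` gives 25 nM. Compound 2 `CN(C)c1nc(NCC2CC2)cc(-c2ccccn2)n1` stands apart: in this assay it reaches only > 25000 nM, which is a limit of the assay rather than a number, namely (the limit of > 25000 nM in this assay, at which 1 of the 3 values shown sits). The unmeasured compound 4 `CNc1nc(NCC2CC2)cc(-c2ccccn2)n1` differs from compound 2 in one place (hydrogen in place of methyl on a nitrogen on an aromatic ring), the same difference, cut one bond further out, reading dimethylamino to methylamino. Among the measured compounds shown here, no measured pair shows this change alone, so its size is open; a move toward smaller amounts is expected, the step from compound 2 to compound 4 being estimated at an at least 5.0-fold lower number from compound 2 to compound 4 (0.69 log units; beyond the scatter). Compound 4 is expected to give about 5000 nM, between 500 nM and 25000 nM.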

Compound 4, half-maximal effective concentration: 164 nM
Compound 4: middle estimate off by 30-fold (1.48 log units), on the high side, and the stated range ends above it.
By their numbers in this assay, from the lowest: compound 3; then compound 1; then compound 4. At a limit, above all of these: compound 2.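

Exchanging one methyl for hydrogen on a nitrogen on an aromatic ring turns out to matter greatly in this assay, giving an at least 150-fold lower number from compound 2 to compound 4 (2.18 log units; beyond the scatter) on this single change. Among the compounds shown here, this is the first comparison here in which only this position differs. As far as these compounds go, the full size of the step stays unknown, since compound 2 has only a limit of the assay and not a number: the limit of > 25000 nM in this assay, at which 1 of the 4 values shown sits.

What the compounds shown leave open is how an unsubstituted amine or an ethylamino group at this position would compare with the methylamino group of compound 4.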